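The source may hold more compounds than are shown below. What is called first, only, known or untested is meant among the compounds shown, and "the series" means these compounds.

Working notes on the series. Compound 1 `COc1ccc(-n2cc3nc(-c4ccccc4C)n(CC4CCCN(C(C)C)C4)c(=O)c3n2)cc1` is the reference for the step considered here. In an assay on HEK293 cells for displacement of a labelled ligand from growth hormone secretagogue receptor type 1 (Homo sapiens), with a stated time of 60 min (on this read-out higher numbers stand for weaker inhibition and lower numbers for stronger inhibition), compound 1 gives 7.3 nM. Compound 2 `COc1cccc(-n2cc3nc(-c4cccnc4C)n(C[C@H]4CCCN(CC5CCOC5)C4)c(=O)c3n2)c1` gives 60 nM in this assay, and compound 3 `COc1cccc(-n2cc3nc(-c4cccnc4C)n(C[C@H]4CCCN(Cc5ccco5)C4)c(=O)c3n2)c1` gives 2.7 nM. Among the three measured numbers compound 1 stands second highest: its nearest neighbour is compound 3, which lies below it beyond the scatter, and the furthest is compound 2, which lies above it beyond the scatter. Among the measured compounds shown here, the only single-point step measured so far, a 22-fold lower number from compound 2 to compound 3 (1.35 log units; beyond the scatter), concerns the group on the amine nitrogen of the saturated ring and not the group on the aromatic nitrogen.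

Compound 4 `Cc1ccccc1-c1nc2cn(-c3cccc(C#N)c3)nc2c(=O)n1CC1CCCN(C(C)C)C1` has not yet been measured. It differs from compound 1 in one place: 3-cyanophenyl in place of 4-methoxyphenyl on an aromatic nitrogen. For the measured compounds named here, no measured pair varies this group alone; compounds 2 and 3 carry a 3-methoxyphenyl there but also differ from compound 1 elsewhere, so their values give nothing separable about it. Going by the values given here, with no step bearing on the change, the expected step is a 1.4-fold higher number from compound 1 to compound 4 (0.14 log units; within the scatter) in this assay, meaning no movement beyond the scatter is assumed, with a correspondingly wide range. Compound 4 is therefore expected to give 10 nM, between 3 nM and 35 nM.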

Compound 4, half-maximal inhibitory concentration in the growth hormone secretagogue receptor type 1 assay: 32 nM
The estimate for compound 4 lay 3.2-fold (0.51 log units) below the measured number, and the stated range covers the measured number.
By their numbers in the growth hormone secretagogue receptor type 1 assay, from the lowest: compound 3; then compound 1; then compounds 4 and 2 (each within the scatter of the next).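

Among the compounds shown here, the group on the aromatic nitrogen, which no earlier pair varied alone, does affect this read-out: in the growth hormone secretagogue receptor type 1 assay, 3-cyanophenyl in place of 4-methoxyphenyl gives a 4.4-fold higher number from compound 1 to compound 4 (0.64 log units; beyond the scatter), although the entering and leaving groups match in heavy-atom count and hydrogen-bond acceptor count. In a physicochemical assay for lipophilicity, using the shake flask method, measured as octanol-water partition, with a stated time of 30 min, at pH 7.4 (a higher number here means a more lipophilic compound, a lower number a more polar compound), compound 1 gives 2.4 and compound 4 gives 1.8. Compound 4 is therefore both the less lipophilic and the weaker inhibitor of this pair, so the change moves both read-outs together, but a single pair cannot show whether the two shifts are linked: the measured distribution coefficient of compound 1, 2.4, and of compound 4, 1.8, a number 0.60 log units lower (beyond the scatter)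

The compounds shown leave open whether the step in the growth hormone secretagogue receptor type 1 assay follows from the nitrile replacing the methoxy group or from the different substitution on the phenyl ring, as the single change from 4-methoxyphenyl to 3-cyanophenyl alters both. A plain phenyl or a 3-carboxyphenyl on the same nitrogen, with the rest of compound 1 unchanged, is also not among these compounds, so how far this position tolerates other groups remains unknown.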